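The compounds below may be only part of what the source reports. "The series", "measured", "known", "first", "only" and "open" are said of these compounds alone.

Measured so far:
Compound 1 `N#Cc1cnc(NCc2ccccc2C(F)(F)F)cc1N[C@H]1CC[C@@H](O)CC1`: 31%
Compound 2 `CO[C@H]1CC[C@@H](Nc2cc(NCc3cnccc3C(F)(F)F)ncc2C#N)CC1`: 1%
Compound 3 `N#Cc1cnc(NCc2ccccc2C(F)(F)F)cc1N[C@H]1C[C@H](C(N)=O)C1`: 54%

These numbers come from an ADME assay on S9 fraction from liver (Rattus norvegicus) for metabolic stability, with a stated time of 1 h; on this read-out higher numbers stand for a more stable compound and lower numbers for a less stable compound. Compound 2 stands lowest of the three, and compound 1 and compound 3 both lie well above it, beyond the usual scatter. The next compound, compound 4 `N#Cc1cnc(NCc2cnccc2C(F)(F)F)cc1N[C@H]1CC[C@@H](C(N)=O)CC1`, differs from compound 2 in one place: carbamoyl in place of methoxy on a saturated ring carbon. In words, carbamoyl stands in place of methoxy on a saturated ring carbon.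

For the measured compounds named here, no measured step makes exactly this swap. The closest is a number 23 percentage points higher from compound 1 to compound 3 (beyond the scatter), a modest rise in which 3-carbamoylcyclobutyl replaces 4-hydroxycyclohexyl. That step also changes the ring and starts from a different group, so it is only a rough guide. Going by the values given here, compound 3, the only measured compound with a carbamoyl group, gives 54%. Compound 2 also shares a part of its structure with compound 4 that compound 1 and compound 3 lack, which keeps the range wide. A rise beyond the scatter is therefore expected, and the expected step is a number 39 percentage points higher from compound 2 to compound 4 (beyond the scatter). For compound 4 the estimated value is 40%, with an expected range of 15% to 70%.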

Compound 4, percent of the compound remaining: 30%
For compound 4 the middle estimate is 10 percentage points above the measured one; low and high end bracket the measured number.
By their numbers in this assay, from the lowest: compound 2; then compounds 4 and 1 (each within the scatter of the next); then compound 3.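

In this assay, for the compounds shown here, the step of a number 29 percentage points higher from compound 2 to compound 4 (beyond the scatter) is the first reading in which only the group on the saturated ring carbon changes, while the six-membered ring and the rest of the molecule stay the same. The earlier carbamoyl step a number 23 percentage points higher from compound 1 to compound 3 (beyond the scatter) also went upward, but it replaced 4-hydroxycyclohexyl with a smaller ring, so ring and group changed together. Nothing measured here explains why the swap from methoxy to carbamoyl raises the number.

Going by these compounds, it remains open how an amine, a carboxylic acid or a longer ether chain at this same place would compare with carbamoyl. Also open is whether this swap would give a similar step on the core of compound 1, since no such pair is shown.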